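Methyl to trifluoromethyl on the pendant phenyl ring

The compounds below may be only part of what the source reports. "The series", "measured", "known", "first", "only" and "open" are said of these compounds alone.

Of the compounds shown here, three sharing one core have been measured in a physicochemical assay for lipophilicity, using the shake flask method, in phosphate buffer, measured as octanol-water partition, with a stated time of 85 min, at pH 7.4; a higher number here means a more lipophilic compound, a lower number a more polar compound. Compound 1 `c1ccc(-c2cn3ccnc3c(-c3ccc4ncn(C5CCCCC5)c4c3)n2)cc1` gives 1.74, compound 2 `c1cn2cc(-c3ccsc3)nc(-c3ccc4ncn(C5CCCCC5)c4c3)c2n1` gives 1.81, and compound 3 `Cc1cccc(-c2cn3ccnc3c(-c3ccc4ncn(C5CCCCC5)c4c3)n2)c1` gives 1.87. Compound 3 sits within the scatter of both others: the step of a number 0.13 log units higher from compound 1 to compound 3 (within the scatter) and the step of a number 0.06 log units higher from compound 2 to compound 3 (within the scatter) are both too small to count as a real difference.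

Compound 4 `FC(F)(F)c1cccc(-c2cn3ccnc3c(-c3ccc4ncn(C5CCCCC5)c4c3)n2)c1` differs from compound 3 in one place: trifluoromethyl in place of methyl on an aromatic carbon. For the measured compounds named here, no measured step exchanges methyl for trifluoromethyl, so there is no direct comparison. The closest measured step, a number 0.13 log units higher from compound 1 to compound 3 (within the scatter), adds a methyl at the same spot and stayed within the scatter, which gives little footing beyond showing that small changes at this position have not moved this assay much so far. Compound 4 is nevertheless expected to land somewhat higher, with an estimated step of a number 0.38 log units higher from compound 3 to compound 4 (beyond the scatter) in this assay. The estimate for compound 4 in this assay is 2.25, with a range from 1.85 to 2.65.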

Compound 4, partition coefficient: 1.72
Estimate against measurement, compound 4: 0.53 log units above; measured number below the stated range.
By their numbers in this assay, from the lowest: compounds 4, 1, 2 and 3 (each within the scatter of the next).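

In this assay, the exchange of methyl for trifluoromethyl, 4 heavy atoms in place of 1, gives a number 0.15 log units lower from compound 3 to compound 4 (within the scatter), so the two groups cannot be told apart on this aromatic carbon. Hydrogen and trifluoromethyl at the same carbon also cannot be told apart, with a number 0.02 log units lower from compound 1 to compound 4 (within the scatter), and exchanging thiophen-3-yl for 3-(trifluoromethyl)phenyl gives a number 0.09 log units lower from compound 2 to compound 4 (within the scatter). The earlier compounds showed this only for methyl and thiophen-3-yl, whereas all four groups now tested in these compounds leave the read-out within the scatter.

From the compounds shown here alone, whether an amine or a carboxylic acid on this carbon would move the number beyond the scatter remains open. No supporting measurement is available to explain why these groups read alike.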